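A Repeated Methoxy Step Measured Against an Assay Limit

A few compounds are considered here, and "the series" means these few. Any claim that something is new, unique, unknown or untested is made for them only; others in the source may bear on it.

compound 1 `CC1=CC[C@H](C(C)(C)NC(=S)N/N=C/c2ccccc2)CC1`: 8700 nM
compound 2 `COc1ccc(/C=N/NC(=S)NC(C)(C)[C@H]2CC=C(C)CC2)cc1`: 7900 nM
compound 3 `CC1=CC[C@H](C(C)(C)NC(=S)N/N=C(\C)c2ccccc2)CC1`: > 100000 nM

In a functional assay on OVCAR-3 cells (Homo sapiens) for inhibition, read by sulforhodamine B assay, with a stated time of 48 h (on this read-out higher numbers stand for weaker inhibition of growth and lower numbers for stronger inhibition of growth), compound 1 gives 8700 nM and compound 2 gives 7900 nM. Compound 2 differs from compound 1 by methoxy in place of hydrogen on an aromatic carbon, and that step measured a 1.1-fold lower number from compound 1 to compound 2 (0.04 log units; within the scatter). In this assay compound 3 is recorded only as a limit, > 100000 nM. For the measured compounds named here, it is the single value sitting at the limit of > 100000 nM in this assay, at which 1 of the 3 values shown sits. The difference between the core of compound 3 and the core of compound 1 is not broken down here.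

Compound 4 `COc1ccc(/C(C)=N/NC(=S)NC(C)(C)[C@H]2CC=C(C)CC2)cc1` has not been measured in this assay. It differs from compound 3 by methoxy in place of hydrogen on an aromatic carbon, the same change that was made from compound 1 to compound 2. Because that earlier step was a 1.1-fold lower number from compound 1 to compound 2 (0.04 log units; within the scatter), the present one is expected to be small as well. Compound 4 is therefore expected to move by about a step that the limit leaves unreadable from compound 3 to compound 4. Compound 4 is expected to give 150000 nM, within 50000 nM to 500000 nM, most likely again reported only as a limit.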

Compound 4, concentration for 50% growth inhibition: 74900 nM
Beside the measured number, compound 4's estimate is 2.0-fold (0.30 log units) above it, and the stated range covers the measured number.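

In this assay compound 3 is recorded only as a limit, > 100000 nM. Going from phenyl to 4-methoxyphenyl on this core gives an at least 1.3-fold lower number from compound 3 to compound 4 (0.12 log units; that floor lies within the scatter), and set beside the same change on the core of compound 1, the result reads: the same change on two cores in this assay, a 1.1-fold lower number (0.04 log units; within the scatter) from compound 1 to compound 2 and an at least 1.3-fold lower number (0.12 log units; that floor lies within the scatter) from compound 3 to compound 4; the limit leaves it open whether they differ Neither printed figure lies beyond the scatter, which fits a change that stays small on both cores, but the second figure is only a floor, so the pair does not show that the change carries the same size from one core to the other.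

The compounds shown leave open whether a hydroxy group or a chlorine atom in place of methoxy on the aromatic ring would give a similar result on either core. They also leave open what a measured value for a close relative of compound 3 would reveal about the difference between the two cores, which is not broken down here.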